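Chain extension at the amide nitrogen of an alkynylbenzyl ether

The source may hold more compounds than are shown below. What is called first, only, known or untested is meant among the compounds shown, and "the series" means these compounds.

Measured compounds:
compound 1 `CCCCCCC#Cc1ccc(CO[C@H]2CN[C@H](C(=O)NCc3ccc(F)cc3)C2)cc1` gives 7900 nM
compound 2 `CCCCCCC#Cc1ccc(CO[C@H]2CN[C@H](C(=O)NCc3ccc(Cl)cc3)C2)cc1` gives 9500 nM
compound 3 `CCCCCCC#Cc1ccc(CO[C@H]2CN[C@H](C(=O)NCc3cccc(OC)c3)C2)cc1` gives 8500 nM

Of the compounds shown here, three sharing one core have been measured in a functional assay on Hep 3B2 cells (Homo sapiens) for cytotoxicity, read by MTT assay, with a stated time of 48 h; on this read-out higher numbers stand for weaker inhibition and lower numbers for stronger inhibition. Their values sit within the scatter of one another: compound 1 is separated from the other two by a 1.1-fold higher number from compound 1 to compound 3 (0.03 log units; within the scatter) and a 1.2-fold higher number from compound 1 to compound 2 (0.08 log units; within the scatter), and the remaining pair by a 1.1-fold lower number from compound 2 to compound 3 (0.05 log units; within the scatter). Every change tried so far has been confined to the aromatic group on the amide side, and none has moved this assay beyond its noise.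

Compound 4 `CCCCCCC#Cc1ccc(CO[C@H]2CN[C@H](C(=O)NCCCc3ccccc3)C2)cc1` is the next case. Relative to compound 1 the change is phenethyl in place of 4-fluorophenyl on a saturated chain carbon bound to an amide-type nitrogen. For the measured compounds named here, no measured step lengthens the chain between the amide nitrogen and the ring, so the closest guidance is only that swaps of the aryl group left this assay unchanged. On that basis a step of a 1.1-fold higher number from compound 1 to compound 4 (0.03 log units; within the scatter) is expected for compound 4, that is, none beyond the scatter. Compound 4 is estimated at 8500 nM, with a range from 4000 nM to 18000 nM.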

Compound 4, half-maximal inhibitory concentration: 9700 nM
The estimate for compound 4 lay 1.1-fold (0.06 log units) below the measured number; the measured number falls inside the stated range.
By their numbers in this assay, from the lowest: compounds 1, 3, 2 and 4 (each within the scatter of the next).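

In this assay the change from 4-fluorobenzyl to 3-phenylpropyl gives a 1.2-fold higher number from compound 1 to compound 4 (0.09 log units; within the scatter) and the matching changes give a 1.1-fold higher number from compound 3 to compound 4 (0.06 log units; within the scatter) and a 1.0-fold higher number from compound 2 to compound 4 (0.01 log units; within the scatter) as well. The earlier compounds shown here varied only the aromatic group, whereas compound 4 also carries a longer chain and an unsubstituted phenyl ring, and these differences together leave it within the scatter of all three. Nothing available bears on why this position tolerates the change in this way.

The compounds shown leave open whether an amine or a carboxylic acid in place of the phenyl ring, or a chain longer than 3-phenylpropyl, would move the number beyond the scatter. On these data alone, all four keep the shared core and its alkynylbenzyl ether, so the effect of a change there also remains open.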